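The source may report more compounds than this note shows. Statements on the series, on what has been measured and on what is new or still open speak of the compounds shown alone.

Compound 1, `N/C(=N\NC(=S)N1CCCCCC1)c1ccccn1`: 67%
Compound 2, `N/C(=N\NC(=S)N1CCSCC1)c1ccccn1`: 61.4%
Compound 3, `N/C(=N\NC(=S)N1CCSCC1)c1ccc(F)cn1`: 61.8%

All three were tested in a functional assay on A-431 cells (Homo sapiens) for cytotoxicity, read by MTT assay, with a stated time of 72 h, tested at 10 uM; a lower number here means less inhibition of growth, a higher number more inhibition of growth at the concentration tested. Compound 1 gives 67%, compound 2 gives 61.4%, and compound 3 gives 61.8%; the three numbers lie within the scatter of one another, so no order among them can be read from them. Compound 2 and compound 3 share a core and differ in one place, (fluoro in place of hydrogen on an aromatic carbon), and the step was a number 0.4 percentage points higher from compound 2 to compound 3 (within the scatter). Compound 1 and compound 2 differ in their cores; the difference between the two cores is not broken down here.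

Compound 4, `N/C(=N\NC(=S)N1CCCCCC1)c1ccc(F)cn1`, has not yet been measured. It differs from compound 1 by fluoro in place of hydrogen on an aromatic carbon, which is the same change as that from compound 2 to compound 3, made at the same kind of place. The expected step is no change at the digits printed from compound 1 to compound 4 (within the scatter) in this assay, because a number 0.4 percentage points higher from compound 2 to compound 3 (within the scatter) for this same change. On that basis compound 4 is expected to give about 67%, most likely between 57% and 77%.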

Compound 4, percent growth inhibition at one concentration: 64.4%
The estimate for compound 4 lay 2.6 percentage points above the measured number; the range from low to high includes it.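

In this assay, fluoro in place of hydrogen on an aromatic carbon of the core of compound 1 gave a number 2.6 percentage points lower from compound 1 to compound 4 (within the scatter). Set beside the earlier step on the other core, the change reads alike on both: the same change on two cores in this assay, a number 0.4 percentage points higher (within the scatter) from compound 2 to compound 3 and a number 2.6 percentage points lower (within the scatter) from compound 1 to compound 4, 3 percentage points apart, within the scatter of two such steps. This shows that, in this one assay at a single concentration, the change carried from one core to the other without either step standing clear of the scatter, but it does not show that fluoro is without effect on growth inhibition in general, and two small steps on two cores cannot establish a rule for the whole series.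

The compounds shown leave open whether a different group on the same aromatic carbon, such as chloro, methoxy, a nitrile or an amine, would give a step beyond the scatter. They also leave open whether fluoro would read the same on a carbon further along the ring or on a core with a smaller saturated ring carrying only carbon and nitrogen.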